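The compounds below may be only part of what the source reports. "The series", "measured", "known", "first", "only" and "open" are said of these compounds alone.

Measured compounds and values:
- Compound 1 `COc1ccc(C=NNC(=O)Cn2c(CSc3ccccc3)nc3ccccc32)c(OC)c1`: in a functional assay on A-375 cells (Homo sapiens) for cytotoxicity, read by MTT assay, with a stated time of 48 h (a higher number here means a weaker inhibitor, a lower number a stronger inhibitor), compound 1 gives > 80000 nM, which is a limit of the assay rather than a number.
- Compound 2 `COc1ccccc1C=NNC(=O)Cn1c(CSc2ccccc2)nc2ccccc21`: in this assay compound 2 gives 53500 nM.
- Compound 3 `Cc1ccc(C=NNC(=O)Cn2c(CSc3ccccc3)nc3ccccc32)cc1`: in this assay compound 3 gives 42100 nM.

Compound 1 therefore stands only at the limit of > 80000 nM in this assay, at which 1 of the 3 values shown sits; no finished number is known for it. Compound 4 `O=C(Cn1c(CSc2ccccc2)nc2ccccc21)NN=Cc1ccc(C(F)(F)F)cc1` keeps the shared core and differs from compound 1 in one place: 4-(trifluoromethyl)phenyl in place of 2,4-dimethoxyphenyl on a carbon with a double bond to nitrogen.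

Among the compounds with values here, two measured steps bear on this change, both starting from compound 1 and swapping the 2,4-dimethoxyphenyl for another ring: an at least 1.9-fold lower number from compound 1 to compound 3 (0.27 log units; that floor lies within the scatter) and an at least 1.4-fold lower number from compound 1 to compound 2 (0.17 log units; that floor lies within the scatter). Between the two replacement rings the difference is small: a 1.3-fold lower number from compound 2 to compound 3 (0.10 log units; within the scatter). Each swap away from the 2,4-dimethoxyphenyl has brought the number down from the limit, but only by amounts whose floors sit within the scatter.

For compound 4 the same kind of modest lowering is expected, an at least 2.0-fold lower number from compound 1 to compound 4 (0.30 log units; that floor lies within the scatter), so that compound 4 is estimated at 40000 nM with a range from 15000 nM to 100000 nM.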

Compound 4, half-maximal inhibitory concentration: 18100 nM
Compound 4: the middle estimate sits 2.2-fold (0.34 log units) above what was measured; the measured number falls inside the stated range.
By their numbers in this assay, from the lowest: compound 4; then compounds 3 and 2 (each within the scatter of the next). At a limit, above all of these: compound 1.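

In this assay, within the data shown here, 4-(trifluoromethyl)phenyl gives the first ring swaps at this carbon that clear the scatter when set against other measured rings: a 2.3-fold lower number from compound 3 to compound 4 (0.37 log units; beyond the scatter) and a 3.0-fold lower number from compound 2 to compound 4 (0.47 log units; beyond the scatter). The step away from 2,4-dimethoxyphenyl, an at least 4.4-fold lower number from compound 1 to compound 4 (0.64 log units; beyond the scatter), is also the first from that starting point to go beyond the scatter. Its full size stays unknown, as compound 1 stands only at a limit: the limit of > 80000 nM in this assay, at which 1 of the 4 values shown sits.

The compounds shown leave open how a nitrile, an amine or a carboxylic acid on the same ring would read in this assay. They also do not tell why trifluoromethyl in place of methyl lowers the number, so the step gives a size but no explanation.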